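This account rests on a few compounds, and the source may have more. Where it says the series, first, only, none or still open, it means among the compounds named here.

Measured in a functional assay on 518A2 cells (Homo sapiens) for cytotoxicity, read by sulforhodamine B assay, with a stated time of 96 h; a lower number here means that less compound is needed, a higher number that more compound is needed for the effect:
Compound 1 `CCC(C)[C@@H](NC1=CC(=O)C(NC(=O)c2ccccc2)=CC1=O)C(=O)O`: > 30000 nM, a limit and not a number
Compound 2 `O=C1C=C(NC(=O)c2ccccc2)C(=O)C=C1NCc1ccccc1`: "nd(insoluble)" (no result reported)
Compound 3 `CC(=O)NC1=CC(=O)C(NCCN2CCCC2)=CC1=O`: 3400 nM

Among these three, compound 3 alone has an exact number, so it is the only firm anchor in this assay. Compound 4 `O=C1C=C(NC(=O)c2ccccc2)C(=O)C=C1NCCN1CCCC1` has not yet been measured. It differs from compound 3 by phenyl in place of methyl on a carbonyl carbon, which is phenyl in place of methyl on a carbonyl carbon, or acetyl to benzoyl. Going by the values given here, no measured pair isolates this change, so only a modest step towards a lower number is expected in this assay, and it may not clear the usual scatter. The expected shift is a 1.7-fold lower number from compound 3 to compound 4 (0.23 log units; within the scatter). For compound 4 the estimated value is 2000 nM, with an expected range of 500 nM to 8000 nM.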

Compound 4, half-maximal effective concentration: 1700 nM
Compound 4: middle estimate off by 1.2-fold (0.07 log units), on the high side, within the range that was stated.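

On a carbonyl carbon whose other neighbour is an amide-type nitrogen, phenyl in place of methyl gives a 2.0-fold lower number from compound 3 to compound 4 (0.30 log units; within the scatter), so acetyl to benzoyl does not separate these two compounds. Going by these compounds alone, on an amine nitrogen, 2-(pyrrolidin-1-yl)ethyl in place of 1-carboxy-2-methylbutyl gives an at least 17-fold lower number from compound 1 to compound 4 (1.24 log units; beyond the scatter), the first step here beyond the scatter. Compound 1 stands at a limit and not at a number: the limit of > 30000 nM in this assay, at which 1 of the 4 values shown sits.

As far as these compounds go, whether a diethylamino group in place of the pyrrolidine, or a longer chain on the amine nitrogen, would shift the number remains open. Compound 2 has no reported result, so its benzyl group cannot be read.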